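Methoxy to amino: a small step expected in clearance

A few compounds are considered here, and "the series" means these few. Any claim that something is new, unique, unknown or untested is made for them only; others in the source may bear on it.

Compound 1 `Cc1cc(Cn2c(=O)[nH]c3c(N)nc(C(F)(F)F)cc32)no1`: < 8 mL.min-1.g-1 (a limit)
Compound 2 `CN1CCN(c2ccc(Cn3c(=O)[nH]c4c(N)nc(C(F)(F)F)cc43)cn2)CC1`: 30 mL.min-1.g-1
Compound 3 `COc1ccc(Cn2c(=O)[nH]c3c(N)nc(C(F)(F)F)cc32)cn1`: < 8 mL.min-1.g-1 (a limit)
Compound 4 `Nc1ccc(Cn2c(=O)[nH]c3c(N)nc(C(F)(F)F)cc32)cn1`: not yet measured

All of these values come from an in vitro ADME assay on microsomes from liver (Homo sapiens) for metabolic stability; on this read-out lower numbers stand for slow clearance and higher numbers for fast clearance. Compound 3 stands at < 8 mL.min-1.g-1, and this is a limit, not a number. Compound 1 stands at the same limit. Compound 4 keeps the core of compound 3 and replaces its methoxy with amino, on an aromatic carbon of a six-membered aromatic ring with 1 nitrogen, next to the ring nitrogen and para to a large group: amino in place of methoxy on an aromatic carbon.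

The closest measured change is an at least 3.7-fold lower number from compound 2 to compound 3 (0.57 log units; beyond the scatter), where methoxy takes the place of 4-methylpiperazin-1-yl on an aromatic carbon. The other measured change, a step that the two limits leave unreadable from compound 1 to compound 3, gives no size to work with. Amino, like methoxy, brings no ring, so the large gap to compound 2 at 30 mL.min-1.g-1 offers little guide here. The estimated change is a number no lower from compound 3 to compound 4 (the limit leaves the size open), which is expected to stay small, with no clear move beyond the scatter. For compound 4 the expected value is 8 mL.min-1.g-1, with an estimated range from 4 mL.min-1.g-1 to 18 mL.min-1.g-1.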

Compound 4, intrinsic clearance in microsomes in the Homo sapiens assay: < 7 mL.min-1.g-1
Compound 4 was reported as a limit (the forecaster's own chance of this, stated with the estimate: 55%); middle value at least 1.1-fold (0.05 log units) from the limit.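

Among the compounds shown here, in the Homo sapiens assay, replacing the 4-methylpiperazin-1-yl group with amino on this aromatic carbon gives an at least 4.2-fold lower number from compound 2 to compound 4 (0.63 log units; beyond the scatter), so methoxy is no longer the only group at this position that reads well apart from compound 2. Compound 1, compound 3 and compound 4 are all reported as limits, and the steps among them cannot be read. What is new is that compound 4 still reads as a limit in the Homo sapiens assay. In a physicochemical assay for lipophilicity, measured as octanol-water partition, at pH 7.4 (a higher number here means a more lipophilic compound, a lower number a more polar compound), compound 3 gives 2.8 and compound 4 gives 1.5, so the change from methoxy to amino leaves compound 4 clearly less lipophilic: the measured distribution coefficient of compound 3, 2.8, and of compound 4, 1.5, a number 1.30 log units lower (beyond the scatter)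

The compounds shown leave open how far the clearance of compound 3 and compound 4 really lies apart, and whether the drop in lipophilicity has any bearing on clearance at all, since a limit hides the true number on each side. They also leave open how clearance behaves for groups of a size between amino and 4-methylpiperazin-1-yl on this aromatic carbon, such as dimethylamino or morpholin-4-yl.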